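This account rests on a few compounds, and the source may have more. Where it says the series, first, only, none or still open, it means among the compounds named here.

Measured compounds:
compound 1, `O=C(O)C1C(C(=O)NCCCc2ccccc2)[C@H]2CC[C@@H]1O2`: 10000 nM
compound 2, `Cc1cc(C)c(NC(=O)C2C(C(=O)O)[C@@H]3CC[C@H]2O3)c(C)c1`: 10000 nM
compound 3, `O=C(O)C1C(C(=O)Nc2ccc(CO)cc2)[C@H]2CC[C@@H]1O2`: 10000 nM

In an ADME assay on BE(2)-C cells (Homo sapiens) for cytotoxicity, read by MTT assay, with a stated time of 72 h (on this read-out lower numbers stand for stronger inhibition of growth and higher numbers for weaker inhibition of growth), compound 1 gives 10000 nM. Compound 2 gives 10000 nM in this assay, and compound 3 gives 10000 nM. Compound 1 thus stands level with compounds 2 and 3 at the digits recorded; on the numbers its nearest neighbour is compound 2 and its furthest is compound 3, and neither gap goes beyond the scatter of repeated measurements of this kind. The structural differences among the three measured compounds do not separate them on this read-out, so no ordering among them can be claimed.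

Compound 4, `CCCCCCCCNC(=O)C1C(C(=O)O)[C@@H]2CC[C@H]1O2`, has not yet been measured in this assay. Compared with compound 1 the change is: pentyl in place of phenyl on a saturated chain carbon, three bonds along the chain from an amide-type nitrogen. Within the data shown here, no step between measured compounds isolates a change of this kind, so the expectation for compound 4 rests only on the flat run of the three recorded values around the shared core. On that basis the step from compound 1 to compound 4 is expected to be none beyond the scatter, no change at the digits printed from compound 1 to compound 4 (within the scatter). Compound 4 is therefore estimated at 10000 nM, within a range of 5000 nM to 20000 nM.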

Compound 4, concentration for 50% growth inhibition: 10000 nM
Compound 4: middle estimate and measured number agree at the digits printed, within the range that was stated.
By their numbers in this assay, from the lowest: compounds 1, 2, 3 and 4 (each within the scatter of the next).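

In this assay the read is no change at the digits printed from compound 1 to compound 4 (within the scatter) for pentyl in place of phenyl on a saturated chain carbon, three bonds along the chain from an amide-type nitrogen. The earlier compounds shown here offered no pair differing in one place, so this is the only direct test in the set, and it shows that at this position the six-membered aromatic ring can give way to an open chain without the value leaving the scatter, with compound 4 at 10000 nM on the shared core. No measurement of any further property bears on this result, and the flat step stands without an explanation.

As far as these compounds go, with a single step and every value level, it remains open whether this position can shift growth inhibition at all, or whether the read-out stays flat for any group placed here. An amine or a carboxylic acid at the end of the chain, or a longer chain such as decyl in place of pentyl, would test this, and none of these groups stands among the compounds shown.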